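Diacylhydrazine series: aryl-to-hexyl swap at one carbonyl

This account rests on a few compounds, and the source may have more. Where it says the series, first, only, none or still open, it means among the compounds named here.

Working notes on a small set of diacylhydrazines with a shared tertiary-butyl-bearing core. Compound 1 `CC(C)(C)N(NC(=O)c1cccc(Cl)c1)C(=O)c1ccccc1Cl` gives 155 nM in an assay on cells for agonist activity at ecdysone receptor (Bombyx mori), read by a luciferase reporter, with a stated time of 24 h; a higher number here means that more compound is needed for the effect, a lower number that less compound is needed. Compound 2 `CC(C)(C)N(NC(=O)c1ccc(Cl)cc1)C(=O)c1ccccc1Cl` gives 115 nM in this assay, and compound 3 `Cc1cc(C)cc(C(=O)N(NC(=O)c2ccc(Cl)cc2)C(C)(C)C)c1` gives 19.1 nM. The step of a 1.3-fold lower number from compound 1 to compound 2 (0.13 log units; within the scatter) lies within the scatter, while the step of a 6.0-fold lower number from compound 2 to compound 3 (0.78 log units; beyond the scatter) is modest but beyond it. Compound 2 thus stands second highest of the three numbers: close to compound 1, with compound 3 clearly lower.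

Compound 4 `CCCCCCC(=O)NN(C(=O)c1ccccc1Cl)C(C)(C)C` is the next member to be measured. It differs from compound 2 in one place: hexyl in place of 4-chlorophenyl on a carbonyl carbon. Within the data shown here, the two measured steps both exchange one aryl group for another aryl group on a carbonyl carbon; neither replaces a ring with a chain, so no measured step bears directly on this change. Among the measured compounds shown here, the available numbers therefore give no precedent of their own, and the expectation rests only on the observation that the measured aryl exchanges moved the number by at most a modest amount. In this assay compound 4 is expected to show a step of a 5.2-fold higher number from compound 2 to compound 4 (0.72 log units; beyond the scatter), toward a higher number with wide uncertainty. Compound 4 is estimated at 600 nM, with a range from 150 nM to 3000 nM.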

Compound 4, half-maximal effective concentration: 741 nM
Beside the measured number, compound 4's estimate is 1.2-fold (0.09 log units) below it; the measured number falls inside the stated range.
By their numbers in this assay, from the lowest: compound 3; then compounds 2 and 1 (each within the scatter of the next); then compound 4.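

In this assay the exchange of a ring for a chain on this carbonyl carbon gives a 6.4-fold higher number from compound 2 to compound 4 (0.81 log units; beyond the scatter) and, read against the 3-chlorophenyl member, a 4.8-fold higher number from compound 1 to compound 4 (0.68 log units; beyond the scatter) as well. Both steps run in the same direction and both lie beyond the scatter, whereas the change from 3-chlorophenyl to 4-chlorophenyl at this place stayed within it (a 1.3-fold lower number from compound 1 to compound 2 (0.13 log units; within the scatter)), so the series now shows that this position responds to losing the aromatic ring and not only to exchanges among aryl groups. Nothing in the data shown accounts for the rise in the number with hexyl at this place.

The compounds shown leave open whether the rise belongs to the absence of a ring or to this particular chain, a question that a cyclohexyl group, a shorter butyl chain or a longer octyl chain on the same carbonyl carbon would help to separate. They also leave open whether hexyl gives a step of the same direction when 3,5-dimethylphenyl replaces 2-chlorophenyl on the other carbonyl carbon, and how a chain ending in an amine or a carboxylic acid would read in this assay at this position.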